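Nitro for methoxy on the aryl ring of compound 3

The source may hold more compounds than are shown below. What is called first, only, known or untested is meant among the compounds shown, and "the series" means these compounds.

Compound 3 `COc1ccc(-c2cc3c(s2)C2(CCN(Cc4ccccc4)CC2)OC(OC)C3)cc1` gives the highest number of the three measured in an assay on membranes from brain for displacement of a labelled ligand from Sigma non-opioid intracellular receptor 1 (Cavia porcellus), read by scintillation counting, with a stated time of 120 min (on this read-out lower numbers stand for stronger inhibition and higher numbers for weaker inhibition), at 56 nM. Compound 2 `COC1Cc2cc(-c3ccccc3)sc2C2(CCN(Cc3ccccc3)CC2)O1` gives 16 nM and compound 1 `COC1Cc2c(csc2-c2ccc(C)cc2)C2(CCN(Cc3ccccc3)CC2)O1` gives 2 nM. Going by the values given here, the only single-point step measured, a 3.5-fold higher number from compound 2 to compound 3 (0.54 log units; beyond the scatter), brought the methoxy in. Compound 4 `COC1Cc2cc(-c3ccc([N+](=O)[O-])cc3)sc2C2(CCN(Cc3ccccc3)CC2)O1` carries the change (nitro in place of methoxy on an aromatic carbon). Among the compounds with values here, no measured step swaps one substituent for another at this place; the only related step is the methoxy entering in place of hydrogen, which raised the number modestly, so compound 4 is expected to move by a 1.2-fold lower number from compound 3 to compound 4 (0.09 log units; within the scatter), with no direction claimable beyond the scatter. For compound 4 the estimate in this assay is 45 nM, with a range from 12 nM to 170 nM.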

Compound 4, inhibition constant: 16 nM
The estimate for compound 4 lay 2.8-fold (0.45 log units) above the measured number, and the stated range covers the measured number.
By their numbers in this assay, from the lowest: compound 1; then compounds 2 and 4 (each within the scatter of the next); then compound 3.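

At this place on the aryl ring, nitro in place of methoxy gives a 3.5-fold lower number from compound 3 to compound 4 (0.54 log units; beyond the scatter), so the higher number of compound 3 does not extend to every group here. Against hydrogen, nitro gives no change at the digits printed from compound 2 to compound 4 (within the scatter), which leaves methoxy as the only one of the three groups that moves the number beyond the scatter. No measurement available here explains the difference between methoxy and nitro.

Going by these compounds, whether an amine or a carboxylic acid at this place would track nitro or methoxy remains open. So does whether nitro would have the same effect on the core of compound 1.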